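This account rests on a few compounds, and the source may have more. Where it says the series, first, only, none or still open, it means among the compounds named here.

Measured so far:
- compound 1 `Cc1ccc(NC(=S)Nc2nc[nH]n2)cc1`: 59000 nM
- compound 2 `S=C(Nc1nc[nH]n1)Nc1ccccc1Br`: > 100000 nM

Within the data shown here, in an ADME assay on MT4 cells (Homo sapiens) for cytotoxicity, read by MTT assay, with a stated time of 96 h (on this read-out lower numbers stand for higher toxicity in this test and higher numbers for lower toxicity in this test), compound 1 gives 59000 nM, the only actual number so far. Compound 2 stands at > 100000 nM, which is a limit of the assay and not a number.

Next in this assay is compound 3 `S=C(Nc1ccc(I)cc1)Nc1nc[nH]n1`, which has iodo in place of methyl on an aromatic carbon of the core of compound 1: iodo in place of methyl on an aromatic carbon. Among the measured compounds shown here, no step between measured compounds is available to size this change, so the expectation rests on compound 1 at 59000 nM. The estimated step of a 1.4-fold lower number from compound 1 to compound 3 (0.15 log units; within the scatter) leans slightly towards lower numbers but is expected to stay within the usual scatter. For compound 3 the expected value is 42000 nM, with an estimated range of 15000 nM to 100000 nM.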

Compound 3, half-maximal cytotoxic concentration: 46000 nM
Estimate against measurement, compound 3: 1.1-fold (0.04 log units) below; measured number inside the range.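

In this assay, among these compounds, iodo in place of methyl on this aromatic carbon, para to a group of 9 heavy atoms, gives a 1.3-fold lower number from compound 1 to compound 3 (0.11 log units; within the scatter) and is the first step that can be read. At this position the two groups are therefore not told apart by this read-out. Compound 3 also adds a second actual number to the series, so the core of compound 1 keeps a measurable value with either group in place.

Going by these compounds, how an amine, a carboxylic acid or a longer chain on this same carbon would read remains open, as does any change elsewhere on the shared core. For compound 2 the value is a limit of the assay and not a number: the limit of > 100000 nM in this assay, at which 1 of the 3 values shown sits.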